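Dimethylamino in place of acetyl on compound 1

The compounds below may be only part of what the source reports. "The series", "measured", "known", "first", "only" and "open" are said of these compounds alone.

Two measured compounds share a core. Compound 1 `COc1cc(C)cc(-c2c(-c3ccnc(-c4ccc(C(C)=O)cc4)c3)cnn2CC#N)c1` in a functional assay on KM12 cells (Homo sapiens) for cytotoxicity, read by sulforhodamine B assay, with a stated time of 48 h, tested at 10 uM (a higher number here means a weaker effect of the compound at the concentration tested, a lower number a stronger effect), gives 10%, the higher of the two numbers. Going by the values given here, compound 2 `COc1cc(C)cc(-c2nn(CC#N)cc2-c2ccnc(-c3ccc(N(C)C)cc3)c2)c1` in this assay gives -70%, a gap beyond the scatter; no single-change step links these two, so their numbers are only set side by side. Compound 3 `COc1cc(C)cc(-c2c(-c3ccnc(-c4ccc(N(C)C)cc4)c3)cnn2CC#N)c1` is compound 1 with one change, (dimethylamino in place of acetyl on an aromatic carbon). Compound 2 carries the same dimethylamino group and gives the lower number. From this the step of a number 50 percentage points lower from compound 1 to compound 3 (beyond the scatter) is expected to be large and downward. Compound 3 is expected to give -40%, within -85% to 5%.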

Compound 3, a percentage reported as activity, at one concentration (the size of the read-out at that concentration, not a potency): -49%
For compound 3 the middle estimate is 9 percentage points above the measured one; the range from low to high includes it.
By their numbers in this assay, from the lowest: compound 2; then compound 3; then compound 1.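

With the rest of compound 1 unchanged, the step of a number 59 percentage points lower from compound 1 to compound 3 (beyond the scatter) in this assay shows that this aromatic carbon, para to a large group, is a position where one substituent change alone moves the read-out beyond the scatter. Acetyl and dimethylamino match in the heavy-atom and hydrogen-bond acceptor counts, so those counts do not separate the two groups. Nothing available gives a cause for the step. From the compounds shown here alone, how a primary amine, a carboxylic acid or a longer chain at this carbon would read remains open.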